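Dropping the hydroxyl from the amine side chain

The source may hold more compounds than are shown below. What is called first, only, known or untested is meant among the compounds shown, and "the series" means these compounds.

Measured so far:
compound 1, `CC(C)[C@@H](O)CNC(C)(C)CC(=O)N[C@@H]1CCc2ccccc2N(Cc2ccc(-c3ccccc3-c3nn[nH]n3)cc2)C1=O`: 200 nM
compound 2, `C[C@@H](O)CCNC(C)(C)C(=O)N[C@@H]1CCc2ccccc2N(Cc2ccc(-c3ccccc3-c3nn[nH]n3)cc2)C1=O`: 100 nM

Both compounds were tested in a functional assay (Pituitary gland cell) with Rattus norvegicus as the target; a lower number here means that less compound is needed, a higher number that more compound is needed for the effect. Compound 2 gives the lower of the two numbers, but the gap to compound 1 lies within the usual scatter, so the two cannot be ranked.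

Compound 3, `CCCNC(C)(C)CC(=O)N[C@@H]1CCc2ccccc2N(Cc2ccc(-c3ccccc3-c3nn[nH]n3)cc2)C1=O`, has not been measured yet. Compared with compound 2 the change is 2-methyl-2-(propylamino)propyl in place of 1-((3-hydroxybutyl)amino)-1-methylethyl on a carbonyl carbon. Going by the values given here, the only measured step, a 2.0-fold lower number from compound 1 to compound 2 (0.30 log units; within the scatter), shows that moving the amine between the two chain arrangements and altering the hydroxylated end of the side chain left the number essentially unchanged. Among the compounds with values here, compound 3 keeps the chain arrangement of compound 1 but carries a plain propyl chain with no hydroxyl; no measured step tests the loss of that hydroxyl. The expected step is therefore small, a 3.0-fold higher number from compound 2 to compound 3 (0.48 log units; beyond the scatter), with the wider uncertainty coming from the untested hydroxyl. Compound 3 is estimated at 300 nM, within a range of 100 nM to 900 nM.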

Compound 3, concentration for half-maximal effect: 50 nM
For compound 3 the middle estimate is 6.0-fold (0.78 log units) above the measured one; measured number outside the range, below it.
By their numbers in this assay, from the lowest: compounds 3, 2 and 1 (each within the scatter of the next, the first and the last beyond it).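

In this assay, going by these compounds alone, putting ethyl in place of 1-hydroxy-2-methylpropyl on a saturated chain carbon bound to an amine nitrogen gives a 4.0-fold lower number from compound 1 to compound 3 (0.60 log units; beyond the scatter), the first step in this set that lies beyond the scatter, so at this position the hydroxylated end of compound 1 is not needed for the effect, and the plain propyl chain on the amine serves better than that end does. The other new step, a 2.0-fold lower number from compound 2 to compound 3 (0.30 log units; within the scatter), lies within the scatter, so compound 2 and compound 3 cannot be ranked, even though the group entering in compound 3 carries no oxygen and no defined stereocentre. Nothing available here explains why the plain chain performs this way.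

On these data alone, the step to compound 3 removes the hydroxyl and the branched end of the chain together, so the share of each stays open, and a propyl chain with only a hydroxyl added would be needed to separate them. As far as these compounds go, how far the chain on the amine can be varied also stays open, for example with a butyl chain, a longer chain still, or a terminal carboxylic acid.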